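Straightening a Branched Chain on Sulfur

This account rests on a few compounds, and the source may have more. Where it says the series, first, only, none or still open, it means among the compounds named here.

compound 1, `COc1ccc(Nc2nccc(-c3sc(SC(C)C)nc3C)n2)c(OC)c1`: 5670 nM
compound 2, `COc1ccc(Nc2nccc(-c3cn(C4CCCC4)c4ccccc34)n2)c(OC)c1`: 1740 nM

Both were tested in a functional assay on MV4-11 cells (Homo sapiens) for inhibition, read by resazurin assay, with a stated time of 72 h; a lower number here means a stronger inhibitor of growth, a higher number a weaker inhibitor of growth. Compound 1 gives 5670 nM, the higher of the two numbers and so the weaker inhibitor of growth; compound 2 gives 1740 nM, and the gap between the two lies beyond the scatter. Compound 3, `CCCSc1nc(C)c(-c2ccnc(Nc3ccc(OC)cc3OC)n2)s1`, has not yet been measured. It holds exactly the atoms of compound 1, joined differently: propyl in place of isopropyl on a sulfur. Within the data shown here, no two measured compounds differ in only one place, so nothing here tells how large such a step is. Exchanging one short chain for another of the same size, with no ring, donor or acceptor gained or lost, is expected to shift the result in this assay by no more than the scatter, in no settled direction. Compound 3 is therefore expected at about 5000 nM, with a likely range from 2000 nM to 13000 nM. This expectation amounts to a step of a 1.1-fold lower number from compound 1 to compound 3 (0.05 log units; within the scatter).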

Compound 3, concentration for 50% growth inhibition: 2240 nM
Estimate against measurement, compound 3: 2.2-fold (0.35 log units) above; measured number inside the range.
By their numbers in this assay, from the lowest: compounds 2 and 3 (each within the scatter of the next); then compound 1.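

Moving from isopropyl to propyl on the sulfur gives a 2.5-fold lower number from compound 1 to compound 3 (0.40 log units; beyond the scatter) in this assay, so this position responds to how the chain is joined and not only to its size. The two chains have the same count of carbons, and neither carries a ring, a donor, an acceptor or a charge, so rearranging the same atoms is enough to give a modest change here. Nothing measured on these compounds explains why the propyl compound has the lower number.

This is a single step, so it cannot show whether the result would carry over to a longer chain such as butyl or to a ring such as cyclopropyl on the sulfur. It also leaves open how this position would respond to a chain ending in an amine or a carboxylic acid.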